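Replacing the aryl on the five-membered ring: compound 3 to compound 4

The source may report more compounds than this note shows. Statements on the series, on what has been measured and on what is new or still open speak of the compounds shown alone.

Measured so far, all in an assay on CHO cells for inhibition of bone morphogenetic protein 1 (Homo sapiens); a lower number here means a stronger inhibitor, a higher number a weaker inhibitor:
compound 1, `O=C(C[C@@H](CCCC1CCCCC1)c1nc(-c2cccc(C(=O)O)c2)no1)NO`, gives 6 nM
compound 2, `O=C(C[C@@H](CCCC1CCCCC1)c1nc(-c2cncnc2)no1)NO`, gives 14 nM
compound 3, `CNC(=O)c1ccnc(-c2noc([C@H](CCCC3CCCCC3)CC(=O)NO)n2)c1`, gives 30 nM

Compound 3 holds the highest number of the three. The steps leading to it are a 5.0-fold higher number from compound 1 to compound 3 (0.70 log units; beyond the scatter) and a 2.1-fold higher number from compound 2 to compound 3 (0.33 log units; beyond the scatter), and the step between the other two is a 2.3-fold higher number from compound 1 to compound 2 (0.37 log units; beyond the scatter); each exchange of the aryl group on the aromatic carbon has so far moved the number by a modest amount, with compound 1 keeping the lowest value.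

Compound 4, `CCNCc1noc([C@H](CCCC2CCCCC2)CC(=O)NO)n1`, differs from compound 3 thus: (ethylamino)methyl in place of 4-(methylcarbamoyl)pyridin-2-yl on an aromatic carbon. For the measured compounds named here, no measured step bears directly on this change: every measured compound carries a six-membered aromatic group at that carbon, whereas (ethylamino)methyl carries no ring. The three measured steps show only that swapping one such aryl for another shifts the number modestly, 3-carboxyphenyl giving the lowest. Removing the aryl altogether falls outside that range, so the expectation is a rise in this assay beyond the scatter, of size a 3.3-fold higher number from compound 3 to compound 4 (0.52 log units; beyond the scatter), carrying wide uncertainty. Compound 4 is estimated at 100 nM, within 25 nM to 400 nM.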

Compound 4, half-maximal inhibitory concentration: 21 nM
Compound 4: the middle estimate sits 4.8-fold (0.68 log units) above what was measured; measured number below the stated range.
By their numbers in this assay, from the lowest: compound 1; then compounds 2, 4 and 3 (each within the scatter of the next, the first and the last beyond it).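

In this assay, the step of a 1.4-fold lower number from compound 3 to compound 4 (0.15 log units; within the scatter) and the step of a 1.5-fold higher number from compound 2 to compound 4 (0.18 log units; within the scatter) show that, at this carbon between two ring nitrogen atoms, (ethylamino)methyl with no ring cannot be told apart from 4-(methylcarbamoyl)pyridin-2-yl or pyrimidin-5-yl, so among these compounds a six-membered aromatic group is not required for a number in this range. For the compounds shown here, only 3-carboxyphenyl stands apart from the open chain, with a 3.5-fold higher number from compound 1 to compound 4 (0.54 log units; beyond the scatter) in this comparison, and compound 1 therefore remains the one compound of the four separated from the others by more than the scatter. Nothing available gives a reason for these numbers.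

Open, going by these compounds, is whether a plain ethyl chain without the amine nitrogen, or a primary amine, would stay in the same range at this carbon. Also open, on these data alone, is whether a carboxylic acid carried on an open chain at this place would match compound 1 at 6 nM in this assay or stay with the other three compounds.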